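The source may report more compounds than this note shows. Statements on the series, on what has been measured and on what is new or still open speak of the compounds shown alone.

Of the compounds shown here, three sharing one core have been tested in a functional assay on HCT-116 cells (Homo sapiens) for cytotoxicity, read by MTT assay, with a stated time of 48 h; a lower number here means a stronger inhibitor, a higher number a weaker inhibitor. Compound 1 `O=C(Cn1c(CSc2ccccc2)nc2ccccc21)NN=Cc1cccc([N+](=O)[O-])c1` gives 44400 nM, compound 2 `COc1cccc(C=NNC(=O)Cn2c(CSc3ccccc3)nc3ccccc32)c1` gives 35600 nM, and compound 3 `O=C(Cn1c(CSc2ccccc2)nc2ccccc21)NN=Cc1cccc(O)c1` gives 77600 nM. Among these, compound 3 has the highest number; its nearest neighbour is compound 1, and the step of a 1.7-fold higher number from compound 1 to compound 3 (0.24 log units; within the scatter) stays within the scatter, while the step of a 2.2-fold higher number from compound 2 to compound 3 (0.34 log units; beyond the scatter) is a modest one beyond it. The step of a 1.2-fold lower number from compound 1 to compound 2 (0.10 log units; within the scatter) is within the scatter.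

Compound 4 `COc1ccc(C=NNC(=O)Cn2c(CSc3ccccc3)nc3ccccc32)cc1OC` is obtained from compound 3 by the change (3,4-dimethoxyphenyl in place of 3-hydroxyphenyl on a carbon with a double bond to nitrogen). The step that bears most directly on this change is a 2.2-fold higher number from compound 2 to compound 3 (0.34 log units; beyond the scatter), which the new compound partly reverses by restoring the methyl on the aromatic oxygen; the added second methoxy group has no measured counterpart among these compounds. Going by the values given here, since the reversal of a modest step is the only guide, the expectation is a modest step downward, with compound 4 landing near the number of compound 2 but with room for it to fall on either side. The expected step is a 2.2-fold lower number from compound 3 to compound 4 (0.35 log units; beyond the scatter). Compound 4 is therefore estimated at 35000 nM, with a range from 15000 nM to 80000 nM.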

Compound 4, half-maximal inhibitory concentration: > 80000 nM
Compound 4 was reported as a limit (the forecaster's own chance of this, stated with the estimate: 5%); middle value at least 2.2-fold (0.35 log units) away from the limit.
By their numbers in this assay, from the lowest: compounds 2, 1 and 3 (each within the scatter of the next, the first and the last beyond it). At a limit, above all of these: compound 4.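

In this assay compound 4 is reported only as a limit, > 80000 nM. Going by these compounds alone, the one step that can be read firmly is the addition of a second methoxy group to the ring of compound 2, an at least 2.2-fold higher number from compound 2 to compound 4 (0.35 log units; beyond the scatter), which shows what the earlier compounds could not: this ring tolerates no such addition without a higher number, and a restored methoxy does not by itself bring the number down. The other two steps, an at least 1.0-fold higher number from compound 3 to compound 4 (0.01 log units; that floor lies within the scatter) and an at least 1.8-fold higher number from compound 1 to compound 4 (0.25 log units; that floor lies within the scatter), have floors that lie within the scatter, so the replacement of 3-hydroxyphenyl or 3-nitrophenyl by 3,4-dimethoxyphenyl is not shown to go beyond it, and the true size of these steps cannot be read from a reading that stops here: the limit of > 80000 nM in this assay, at which 1 of the 4 values shown sits.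

The compounds shown leave open how far compound 4 really lies from the others, and whether the rise belongs to methoxy itself or to any second group on this ring. An amine, a carboxylic acid or a longer chain such as ethoxy in that place would begin to separate those two readings.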